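The source may report more compounds than this note shows. Statements on the series, on what has been measured and on what is new or still open speak of the compounds shown alone.

Measured so far:
- compound 1 `CCOC(=O)CC(=O)N1CCSC1COc1ccccc1OC`: 11 mg/kg
- compound 2 `COc1ccccc1OCC1N(C(=O)C[S+](C)[O-])CC[S+]1[O-]`: 25 mg/kg

In a functional assay on the whole organism (trachea) for inhibition, with Cavia porcellus as the target (on this read-out lower numbers stand for an effect already at smaller amounts and higher numbers for an effect only at larger amounts of compound), compound 1 gives 11 mg/kg and stands lowest of the two numbers at hand. Its nearest neighbour is compound 2, which in this assay gives 25 mg/kg, a number that lies beyond the scatter of repeated runs. For the measured compounds named here, the two compounds differ in more than one place, so no single step between them is defined, and only their two values are available to the reader.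

Compound 3 `COc1ccccc1OCC1SCCN1C(=O)COC(C)=O` is not yet measured in this assay. It differs from compound 1 in one place:

acetoxy in place of ethoxycarbonyl on a saturated chain carbon bound to a carbonyl carbon

Going by the values given here, no measured pair shows what such an exchange does here, and the data on compound 2 do not isolate it. With nothing in the numbers pointing either way, the account expects the step from compound 1 to compound 3 to be small, at most on the edge of the scatter, with no set direction; the expected step is a 1.2-fold higher number from compound 1 to compound 3 (0.07 log units; within the scatter). Compound 3 is accordingly estimated at 13 mg/kg, with a range from 5 mg/kg to 35 mg/kg.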

Compound 3, dose for half-maximal effect: 25 mg/kg
Beside the measured number, compound 3's estimate is 1.9-fold (0.28 log units) below it; the range from low to high includes it.
By their numbers in this assay, from the lowest: compound 1; then compounds 2 and 3 (each within the scatter of the next).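

Putting acetoxy in place of ethoxycarbonyl on a saturated chain carbon bound to a carbonyl carbon gives a 2.3-fold higher number from compound 1 to compound 3 (0.36 log units; beyond the scatter) in this assay, so this position responds to the exchange, though modestly, and the lower number goes with ethoxycarbonyl. The two groups match in their counts of hydrogen-bond donors and acceptors, and neither carries a ring or a net charge, so these matching counts do not keep the number in place. Nothing available here explains the shift.

On these data alone, it remains open whether methoxycarbonyl, a shorter relative of ethoxycarbonyl, would read like the ethoxycarbonyl or like the acetoxy group at this position. As far as these compounds go, how a carboxylic acid or a primary amine would read there in this assay is equally open.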